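The source may hold more compounds than are shown below. What is called first, only, known or untested is meant among the compounds shown, and "the series" means these compounds.

Every compound in this study passes through a toxicity assay on THP-1 cells (Homo sapiens) for inhibition; a higher number here means that more compound is tolerated, a lower number that less compound is tolerated. Compound 1 `COc1ccc(-c2cnc(NC(=O)c3ncc[nH]3)n2C)cc1` gives > 100000 nM in this assay, which is a limit of the measurement rather than a number. Compound 2 `Cn1c(-c2ccccc2F)cnc1NC(=O)c1ccc(F)cc1` also reaches only a limit, > 100000 nM. Compound 3 `Cn1cc(-c2ccccc2)nc1NC(=O)c1ccc(F)cc1` likewise stops at a limit, > 50000 nM. Compound 1 thus stands at the limit of > 100000 nM in this assay, at which 2 of the 3 values shown sit. The remaining value, that of compound 3, sits at the limit of > 50000 nM in this assay, at which 1 of the 3 values shown sits. Among the measured compounds shown here, because none of the three values is a number, no step between measured compounds can be sized, and the three simply show that large amounts of each are tolerated.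

Compound 4 `COc1ccc(-c2cnc(NC(=O)c3ccco3)n2C)cc1` differs from compound 1 in one place: furan-2-yl in place of 1H-imidazol-2-yl on a carbonyl carbon. For the measured compounds named here, with no measured step to lean on, the expectation is that this change moves this assay by no more than the scatter, in neither direction, so the expected step is a number no higher from compound 1 to compound 4 (the limit leaves the size open). Compound 4 is therefore expected to give about 100000 nM, within a range from 50000 nM to 200000 nM, and most likely again only a limit.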

Compound 4, half-maximal cytotoxic concentration: > 100000 nM
Compound 4 gave a limit, no number; the forecaster's own chance of this, stated with the estimate: 80%; the middle value sits exactly at the limit.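

Compound 1 and compound 4 both stop at a limit in this assay, not at a number, so the step between them cannot be read. The compounds shown leave open the concentration at which any of them becomes half-maximally cytotoxic, and whether furan-2-yl and 1H-imidazol-2-yl differ at all.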